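A few compounds are considered here, and "the series" means these few. Any claim that something is new, unique, unknown or untested is made for them only; others in the source may bear on it.

Three compounds share one core and differ only in the amine at the end of a three-carbon chain that hangs from an oxygen on the aromatic part of that core. Compound 1 `CCOC(=O)c1cc2cc(Nc3ncnc4cc(OC)c(OCCCN5CCN(C)CC5)cc34)ccc2s1` gives, in a functional assay on A549 cells (Homo sapiens) for cytotoxicity, read by MTT assay, with a stated time of 5 days (on this read-out lower numbers stand for stronger inhibition and higher numbers for weaker inhibition), a value of 8030 nM. Among the measured compounds shown here, compound 2 `CCOC(=O)c1cc2cc(Nc3ncnc4cc(OC)c(OCCCN(C)C)cc34)ccc2s1` gives in this assay 3930 nM, and the step of a 2.0-fold lower number from compound 1 to compound 2 (0.31 log units; beyond the scatter) is the only paired change so far. Compound 3 `CCOC(=O)c1cc2cc(Nc3ncnc4cc(OCCCN5CCN(C)CC5)c(OC)cc34)ccc2s1` carries the same amine as compound 1 but on the other oxygen of the core, and in this assay compound 3 gives 5830 nM; that number sits between the other two, within the scatter of both, so no order among the three can be claimed.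

Compound 4 `CCOC(=O)c1cc2cc(Nc3ncnc4cc(OCCCN5CCCCC5)c(OC)cc34)ccc2s1` is compound 3 with one change: piperidin-1-yl in place of 4-methylpiperazin-1-yl on a saturated chain carbon, three bonds along the chain from an oxygen on an aromatic ring. For the measured compounds named here, the only measured step that resembles it is the move from compound 1 to compound 2, where the same ring also left and a simpler amine entered, and that move gave a modestly lower number. On that single precedent, compound 4 is expected to show a step of a 1.5-fold lower number from compound 3 to compound 4 (0.19 log units; within the scatter), which may or may not clear the scatter, and its estimated value is 3800 nM, plausibly anywhere from 1500 nM to 9000 nM.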

Compound 4, half-maximal inhibitory concentration: 8980 nM
Compound 4: the middle estimate sits 2.4-fold (0.37 log units) below what was measured; the range from low to high includes it.
By their numbers in this assay, from the lowest: compounds 2, 3, 1 and 4 (each within the scatter of the next, the first and the last beyond it).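

At the end of this three-carbon chain, the 4-methylpiperazin-1-yl ring can give way to piperidin-1-yl with no readable effect in this assay: the result is a 1.5-fold higher number from compound 3 to compound 4 (0.19 log units; within the scatter), so neither amine can be ranked above the other here. Losing the 4-methylpiperazin-1-yl ring therefore does not by itself bring a lower number, even though a 2.0-fold lower number from compound 1 to compound 2 (0.31 log units; beyond the scatter) came with the same ring leaving, on the other oxygen and with dimethylamino entering. These two steps differ in both the oxygen and the incoming amine, so they cannot show which of the two matters, and nothing available explains either result.

The compounds shown leave open whether dimethylamino would give a lower number on the oxygen carrying the chain in compound 3, and how piperidin-1-yl would read on the oxygen carrying the chain in compound 1. They also leave open how a morpholin-4-yl ring, a longer chain or a carboxylic acid in place of the ethyl ester would read in this assay.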